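The source may report more compounds than this note shows. Statements on the series, on what has been measured and on what is new or still open speak of the compounds shown alone.

Measured so far in an ADME assay on cells for inhibition of cytochrome P450 11B1, mitochondrial (Homo sapiens), read by HTRF, with stated times of 1 h and 3 h; a higher number here means a weaker inhibitor, a lower number a stronger inhibitor:
compound 1 `CC(C)(O)c1cncc(-n2ncc3ccccc32)c1` gives 535 nM;
compound 2 `CC(C)(O)c1cncc(-n2ncc3cccc(F)c32)c1` gives 10.7 nM;
compound 3 `CC(C)(O)c1cncc(-n2ncc3cc(C(F)(F)F)ccc32)c1` gives 1200 nM.

Among these three numbers compound 1 stands second highest in this assay: compound 3 lies nearest to it, a little higher, and compound 2 lies furthest from it, far lower. Compound 4 `Cc1cccc2c1cnn2-c1cncc(C(C)(C)O)c1` has not yet been measured. It differs from compound 1 by methyl in place of hydrogen on an aromatic carbon.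

Among the compounds with values here, two measured steps bear on this change, both being the replacement of a hydrogen on the same carbocyclic ring of the shared core. The first, a 50-fold lower number from compound 1 to compound 2 (1.70 log units; beyond the scatter), was large and downward. The second, a 2.2-fold higher number from compound 1 to compound 3 (0.35 log units; beyond the scatter), was modest and upward. A methyl is neither a fluoro nor a trifluoromethyl, and nothing here shows how a methyl itself behaves on this ring, so the two steps pull in opposite directions and leave the outcome open. The step from compound 1 to compound 4 is therefore expected to be small, most likely a 1.5-fold lower number from compound 1 to compound 4 (0.18 log units; within the scatter), with a wide range. For compound 4 the estimate in this assay is 350 nM, expected to fall between 90 nM and 1500 nM.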

Compound 4, half-maximal inhibitory concentration: 210 nM
Estimate against measurement, compound 4: 1.7-fold (0.22 log units) above, within the range that was stated.
By their numbers in this assay, from the lowest: compound 2; then compound 4; then compound 1; then compound 3.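

In this assay, methyl on this aromatic carbon, ortho to a fused ring and meta to a fused ring, gives a 2.5-fold lower number from compound 1 to compound 4 (0.41 log units; beyond the scatter). Within the data shown here, none of the earlier compounds carries a group on this carbon, so this is the first sign that a substituent placed here is accepted and moves the number downward, beyond the scatter, though only modestly. No measurement offered here accounts for this step, and its cause stays unexplained.

The compounds shown do not tell whether fluoro, methoxy, chloro or an amine on this same carbon would lower the number further or raise it. They also leave open how methyl itself would behave on the carbons that bear fluoro in compound 2 and trifluoromethyl in compound 3.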